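The compounds below may be only part of what the source reports. "The series", "measured", "known", "first", "only" and "open" are said of these compounds alone.

Measured compounds:
Compound 1 `COc1ccc2cc(C(C)c3nnc4n3N=C(c3ccc([N+](=O)[O-])cc3)CS4)ccc2c1` — in a functional assay on HCT-116 cells (Homo sapiens) for inhibition, read by sulforhodamine B assay, with a stated time of 72 h (on this read-out lower numbers stand for stronger inhibition and higher numbers for weaker inhibition), compound 1 gives 15100 nM
Compound 2 `COc1ccc2cc(C(C)c3nnc4n3N=C(c3ccc(Br)cc3)CS4)ccc2c1` — in this assay compound 2 gives 11700 nM
Compound 3 `CC(c1ccc(-c2ccccc2)c(F)c1)c1nnc2n1N=C(c1ccc(Cl)cc1Cl)CS2` — in this assay compound 3 gives 6900 nM

Among these three numbers compound 2 stands second highest. Its nearest neighbour is compound 1, and the step of a 1.3-fold lower number from compound 1 to compound 2 (0.11 log units; within the scatter) shows that the two lie within the scatter of each other. Compound 3, the furthest of the three, also lies within the scatter of compound 2, so no order among them can be claimed.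

Compound 4 `COc1ccc2cc(C(C)c3nnc4n3N=C(c3ccc(Cl)cc3)CS4)ccc2c1` has not yet been measured. It differs from compound 2 in one place only: chloro in place of bromo on an aromatic carbon. Among the measured compounds shown here, the only measured step that touches this position is the one from compound 1 to compound 2, an exchange of nitro for bromo, and it stayed within the scatter. A swap of one halogen for another at the same place is a smaller change still, so no step beyond the scatter is expected in this assay in either direction.

For compound 4 the expected value in this assay is therefore 12000 nM, with a range from 6000 nM to 25000 nM, which means an expected step of a 1.0-fold higher number from compound 2 to compound 4 (0.01 log units; within the scatter).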

Compound 4, half-maximal inhibitory concentration: 8800 nM
Compound 4: middle estimate off by 1.4-fold (0.13 log units), on the high side; the range from low to high includes it.
By their numbers in this assay, from the lowest: compounds 3, 4, 2 and 1 (each within the scatter of the next, the first and the last beyond it).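

Exchanging the 4-bromophenyl for the 4-chlorophenyl gives a 1.3-fold lower number from compound 2 to compound 4 (0.12 log units; within the scatter) in this assay and so separates the two halogens no more than the nitro-to-bromo exchange separated its pair. The comparison of chloro with nitro gives a 1.7-fold lower number from compound 1 to compound 4 (0.23 log units; within the scatter) and shows that all three groups tried on this aromatic carbon, para to a large group, lie within the scatter of one another. Nothing available here bears on why these three groups read alike.

On these data alone, whether an amine or a carboxylic acid at this place would also stay within the scatter remains open. As far as these compounds go, it is equally open whether the exchange of bromo for chloro would read the same way on the core of compound 3 .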